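This account rests on a few compounds, and the source may have more. Where it says the series, first, only, none or still open, it means among the compounds named here.

In an ADME assay on microsomes from liver (Mus musculus) for metabolic stability, using NADPH, with a stated time of 10 min (a lower number here means that less of the compound is left, a higher number that more of the compound is left), compound 1 `CN(C[C@H]1Cc2ncccc2CN1)[C@H]1CCCc2cccnc21` gives 53% and compound 2 `NC/C=C\CN(C[C@H]1Cc2ncccc2CN1)[C@H]1CCCc2cccnc21` gives 37%, so compound 2 holds the lower of the two numbers, with the gap beyond the scatter.

The next structure is compound 3 `NC(=O)NCCCCN(C[C@H]1Cc2ncccc2CN1)[C@H]1CCCc2cccnc21`, which keeps the shared core and differs from compound 2 in one group: 3-ureidopropyl in place of 3-aminoprop-1-en-1-yl on a saturated chain carbon bound to an amine nitrogen. In words, 3-ureidopropyl stands in place of 3-aminoprop-1-en-1-yl on a saturated chain carbon bound to an amine nitrogen.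

Among the compounds with values here, only one measured step bears on this change: a number 16 percentage points lower from compound 1 to compound 2 (beyond the scatter). That modest step records a different replacement, 3-aminoprop-1-en-1-yl in place of hydrogen at this kind of carbon. Within the data shown here, no measured compound carries 3-ureidopropyl, so the data give no direction for the new group. With a substituent retained at this place, no step beyond the scatter is expected, and the range stays wide in both directions.

The expected step is small: a number 3 percentage points higher from compound 2 to compound 3 (within the scatter). In this assay, the estimate for compound 3 is 40%, with an expected range of 22% to 60%.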

Compound 3, percent of the compound remaining: 32%
Beside the measured number, compound 3's estimate is 8 percentage points above it, and the stated range covers the measured number.
By their numbers in this assay, from the lowest: compounds 3 and 2 (each within the scatter of the next); then compound 1.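

In the series, the replacement at this place on a saturated chain carbon bound to an amine nitrogen now has a second substituent to set against hydrogen in this assay (a number 21 percentage points lower from compound 1 to compound 3 (beyond the scatter)), and it too lies beyond the scatter, so the drop seen with compound 2 is not confined to 3-aminoprop-1-en-1-yl. Exchanging that group for 3-ureidopropyl, which has more heavy atoms and an additional hydrogen-bond donor, leaves the two substituents indistinguishable in this read-out (a number 5 percentage points lower from compound 2 to compound 3 (within the scatter)), so neither the size of the group nor its end can yet be tied to the number. No measurement at hand explains these numbers.

Whether the chain itself or its nitrogen-bearing end accounts for the gap to compound 1 stays open, and a plain butyl chain, with no heteroatom at its end, would bear on that question. A saturated 4-aminobutyl group or a chain ending in a carboxylic acid at the same place would show whether the double bond or the type of end group matters at all.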